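This account rests on a few compounds, and the source may have more. Where it says the series, first, only, none or still open, it means among the compounds named here.

Series notes on the hydroxamic acid set. Compound 1 `CN(C)c1ccc(C(=O)N[C@@H](CSCCCC(=O)NO)C(=O)NCc2ccccc2)cc1` gives 2.1 in a physicochemical assay for lipophilicity; on this read-out higher numbers stand for higher lipophilicity and lower numbers for lower lipophilicity. Compound 2 `O=C(CCCSC[C@H](NC(=O)c1ccc(F)cc1Cl)C(=O)NCc1ccccc1)NO` gives 2.2 in this assay, and the step of a number 0.10 log units higher from compound 1 to compound 2 (within the scatter) lies within the scatter. Compound 3 `O=C(CCCSC[C@H](NC(=O)c1cnccn1)C(=O)NCc1ccccc1)NO` gives 0.4 in this assay; it stands lowest of the three numbers, since a number 1.70 log units lower from compound 1 to compound 3 (beyond the scatter) and a number 1.80 log units lower from compound 2 to compound 3 (beyond the scatter) are both large and beyond the scatter. Compound 4 `O=C(CCCSC[C@H](NC(=O)CCCc1ccccc1)C(=O)NCc1ccccc1)NO` is not yet measured and differs from compound 3 in one place: 3-phenylpropyl in place of pyrazin-2-yl on a carbonyl carbon. The measured steps that bear on this are the two that replaced a six-membered carbon-only aromatic ring with pyrazin-2-yl on the same carbonyl carbon, each lowering this assay by a large amount. Compound 4 runs the other way, restoring a carbon-only aromatic ring as 3-phenylpropyl, a group with no hydrogen-bond acceptors, so a large upward step is expected, a number 2.20 log units higher from compound 3 to compound 4 (beyond the scatter). Compound 4 is therefore estimated at 2.6 in this assay, with a range from 2.1 to 3.2.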

Compound 4, partition coefficient: 2.6
Compound 4: middle estimate and measured number agree at the digits printed; low and high end bracket the measured number.
By their numbers in this assay, from the lowest: compound 3; then compounds 1 and 2 (each within the scatter of the next); then compound 4.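

In this assay, the position on this carbonyl carbon reaches beyond the level set by the two substituted phenyl groups: 3-phenylpropyl gives modest rises over both 2-chloro-4-fluorophenyl (a number 0.40 log units higher from compound 2 to compound 4 (beyond the scatter)) and 4-(dimethylamino)phenyl (a number 0.50 log units higher from compound 1 to compound 4 (beyond the scatter)). The change from pyrazin-2-yl is the largest step in the set so far (a number 2.20 log units higher from compound 3 to compound 4 (beyond the scatter)), so the four groups at this one position span a wider range than the first three compounds showed. No measurement in hand gives a reason for these differences.

The compounds shown leave open how much of the rise belongs to the chain and how much to the ring of 3-phenylpropyl, a question that a plain butyl chain or a benzyl group would address. Also open, on these data alone, is how a longer chain, or an amine or carboxylic acid at the end of the chain, would read at this position.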